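Ethoxycarbonyl for Sulfamoyl: Expected Cytotoxicity of Compound 4

The source may hold more compounds than are shown below. What is called first, only, known or untested is meant among the compounds shown, and "the series" means these compounds.

Three compounds have been tested in a toxicity assay on MT4 cells (Homo sapiens) for cytotoxicity, read by MTT assay, with a stated time of 5 days; a lower number here means that less compound is tolerated, a higher number that more compound is tolerated:

Compound 1 `Cc1ccc(C(C)C)c(OCC(=O)NNC(=S)NCc2ccccc2)c1` gives 12.6 ug/mL.
Compound 2 `O=C(COc1ccc2ccccc2c1)NNC(=S)NCc1ccccc1` gives only the limit of the assay, >= 61.4 ug/mL.
Compound 3 `Cc1ccc(C(C)C)c(OCc2nnc(SCC(=O)Nc3ccc(S(N)(=O)=O)cc3)n2Cc2ccccc2)c1` gives 13 ug/mL.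

Compound 3 is one of two compounds with a numerical value in this assay, and its value lies within the usual scatter of that of compound 1, so the two cannot be ranked. Compound 4 `CCOC(=O)c1ccc(NC(=O)CSc2nnc(COc3cc(C)ccc3C(C)C)n2Cc2ccccc2)cc1` is not yet measured. It differs from compound 3 in one place: ethoxycarbonyl in place of sulfamoyl on an aromatic carbon. Within the data shown here, no measured pair shows this change, so the expectation rests on compound 3 alone. The expected step is small, a 1.2-fold higher number from compound 3 to compound 4 (0.06 log units; within the scatter), with no clear direction beyond the scatter. Compound 4 is therefore estimated at 15 ug/mL, between 7 ug/mL and 35 ug/mL.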

Compound 4, half-maximal cytotoxic concentration: 19.8 ug/mL
Beside the measured number, compound 4's estimate is 1.3-fold (0.12 log units) below it; the measured number falls inside the stated range.
By their numbers in this assay, from the lowest: compounds 1, 3 and 4 (each within the scatter of the next). At a limit, above all of these: compound 2.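

In this assay, among these compounds, ethoxycarbonyl in place of sulfamoyl on an aromatic carbon, para to a large group, gives a 1.5-fold higher number from compound 3 to compound 4 (0.18 log units; within the scatter) as the only step measured at this position. The two compounds cannot be told apart in this assay, even though the sulfamoyl group, with its sulfur, its nitrogen and its hydrogen-bond donor, is gone from compound 4. Nothing in the data at hand explains this result.

Still open, going by these compounds, is whether an amine or a carboxylic acid at the same position would also stay within the scatter of compound 3. The same question applies to a longer chain on the ester.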